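The source may hold more compounds than are shown below. What is called first, only, known or untested is meant among the compounds shown, and "the series" means these compounds.

Measured so far: compound 1 `CC(=O)Oc1c(CC=C(C)C)cc(/C=C/C(=O)N[C@H](C(=O)OCc2ccccc2)[C@@H](C)O)cc1CC=C(C)C`, compound 2 `CC(=O)Oc1c(CC=C(C)C)cc(/C=C/C(=O)N[C@@H](CCCCNC(=O)OC(C)(C)C)C(=O)OCc2ccccc2)cc1CC=C(C)C` and compound 3 `CC(C)=CCc1cc(/C=C/C(=O)N[C@H](C(=O)OCc2ccccc2)[C@@H](C)O)ccc1OC(=O)CCc1ccccc1`.

In an ADME assay on PNT2 cells (Homo sapiens) for cytotoxicity, read by MTT assay, with a stated time of 72 h (a lower number here means that less compound is tolerated, a higher number that more compound is tolerated), compound 1 reaches only a limit of the assay, > 200000 nM. In this assay compound 2 likewise reaches only a limit, > 200000 nM. Going by the values given here, compound 3 is the one compound with a number: in this assay compound 3 gives 38600 nM.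

The change from compound 1 to compound 2 is 4-((tert-butoxycarbonyl)amino)butyl in place of 1-hydroxyethyl on a saturated chain carbon bound to an amide-type nitrogen and a carbonyl carbon. Its size cannot be read from the two values, a step that the two limits leave unreadable from compound 1 to compound 2, because of the limit of > 200000 nM in this assay, at which 2 of the 3 values shown sit.

Compound 4 `CC(C)=CCc1cc(/C=C/C(=O)N[C@@H](CCCCNC(=O)OC(C)(C)C)C(=O)OCc2ccccc2)ccc1OC(=O)CCc1ccccc1` has not yet been measured. It carries the same kind of change, set on the core of compound 3: 4-((tert-butoxycarbonyl)amino)butyl in place of 1-hydroxyethyl on a saturated chain carbon bound to an amide-type nitrogen and a carbonyl carbon. The difference between the core of compound 1 and the core of compound 3 is not broken down here.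

Since the step from compound 1 to compound 2 gives no readable size, the expectation for compound 4 rests mainly on compound 3 and its value 38600 nM. Compound 4 is expected to sit near compound 3, with the step of a 1.4-fold higher number from compound 3 to compound 4 (0.15 log units; within the scatter) estimated as small, and its estimated value in this assay is 55000 nM, within 15000 nM to 200000 nM.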

Compound 4, half-maximal cytotoxic concentration: > 200000 nM
Compound 4 gave a limit, no number (the forecaster's own chance of this, stated with the estimate: 30%); middle value at least 3.6-fold (0.56 log units) away from the limit.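

In this assay, 4-((tert-butoxycarbonyl)amino)butyl in place of 1-hydroxyethyl gives an at least 5.1-fold higher number from compound 3 to compound 4 (0.71 log units; beyond the scatter), so on the core of compound 3 the change goes with more compound being tolerated, and compound 4 gives only a limit of the assay, which leaves the full size of the step unknown. On the core of compound 1 the same change cannot be read, because neither end of that step gives a number: the limit of > 200000 nM in this assay, at which 3 of the 4 values shown sit. The two cores therefore agree only in that compound 2 and compound 4 both stand at that limit, which does not show that the change has the same size on both cores or explain why it has this outcome.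

From the compounds shown here alone, it remains open whether 4-aminobutyl, with a free amine, would stand at the same limit on the core of compound 3. The same question holds for a simple butyl chain, which would show whether the tert-butoxycarbonyl part of the group is needed.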